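The compounds below may be only part of what the source reports. "The series", "measured", "known", "first", "only" and "open" are said of these compounds alone.

Working notes on the series, values from a physicochemical assay for lipophilicity, using the shake flask method; a higher number here means a more lipophilic compound, a lower number a more polar compound:
- compound 1 `C[C@H](Oc1ccc2ncc(/C=C/C(=O)O)c(C3CC3)c2c1)c1c(Cl)cccc1Cl` reads 3.7
- compound 2 `C[C@H](Oc1ccc2ncc(/C=C/C(=O)O)cc2c1)c1c(Cl)ccc(F)c1Cl` reads 2.5
- compound 3 `C[C@H](Oc1ccc2ncc(/C=C/c3nn[nH]n3)c(C(F)F)c2c1)c1c(Cl)cccc1Cl` reads 3.3

Compound 2 holds the lowest of the three numbers. Compound 3 at 3.3 and compound 1 at 3.7 both stand above it, each beyond the scatter.

Compound 4 `C[C@H](Oc1ccc2ncc(/C=C/C(=O)O)c(-n3ccnc3)c2c1)c1c(Cl)ccc(F)c1Cl` is compound 2 with 1H-imidazol-1-yl in place of hydrogen on an aromatic carbon, opposite the ring nitrogen and ortho to a 2-carboxyethenyl group (1H-imidazol-1-yl in place of hydrogen on an aromatic carbon). Going by the values given here, no measured pair shows a change made in one place, so nothing measured gives this step directly. Compound 1 and compound 3 also carry a group at this place, but each differs from compound 2 in other ways too, and their higher numbers cannot be read as the effect of that place alone.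

The estimate therefore starts from compound 2 at 2.5 and keeps a wide range. The expected step in this assay is small and downward, not beyond the scatter, and the estimated size of a number 0.10 log units lower from compound 2 to compound 4 (within the scatter) is only a working figure. For compound 4 the estimated value is 2.4 with an expected range from 1.9 to 2.9 in this series.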

Compound 4, distribution coefficient: 2
Compound 4: the middle estimate sits 0.40 log units above what was measured; the range from low to high includes it.
By their numbers in this assay, from the lowest: compound 4; then compound 2; then compound 3; then compound 1.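

In this assay, going by these compounds alone, placing 1H-imidazol-1-yl on the aromatic carbon opposite the ring nitrogen and ortho to a 2-carboxyethenyl group gives a number 0.50 log units lower from compound 2 to compound 4 (beyond the scatter) and provides the first reading of a change made at this place alone. This place therefore accepts an aromatic ring of 5 heavy atoms, with 2 hetero atoms and no net charge, while the number goes down, so a group here does not have to go with a higher number in this assay. The compounds shown offer no measurement that explains the size or direction of this step.

One pair cannot show whether the step belongs to this particular ring or would recur with a different group at the same place, such as an amine, a methoxy group or a phenyl ring on the core of compound 2. Also open, going by these compounds, is whether 1H-imidazol-1-yl would give a step of similar size and direction on a compound with a different substitution pattern on the dichlorophenyl ring, or with a different chain in place of the 2-carboxyethenyl group.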